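The source may report more compounds than this note shows. Statements on the series, on what has been measured and on what is new or still open speak of the compounds shown alone.

Of the compounds shown here, three measured so far share one core. Compound 1 `O=C1CCC/C1=C\c1ccc(OC2CCCC2)cc1`, compound 2 `Cc1ccc(C(=O)/C=C/c2ccc(OC3CCCC3)cc2)cc1` and compound 3 `CN1CCC(=O)/C(=C/c2ccc(OC3CCCC3)cc2)C1` were each tested in a functional assay on PC-3 cells (Homo sapiens) for antiproliferative activity, read by MTT assay; on this read-out higher numbers stand for weaker inhibition and lower numbers for stronger inhibition. Compound 1 gives 94100 nM, compound 2 gives 17100 nM and compound 3 gives 10500 nM. Compound 2 thus lies within the scatter of compound 3, while its gap to compound 1 is beyond the scatter. Compound 4 `CC(=O)/C=C/c1ccc(OC2CCCC2)cc1` has not yet been measured in this assay. It differs from compound 2 at a single place: methyl in place of 4-methylphenyl on a carbonyl carbon. Among the measured compounds shown here, no measured pair moves this same group, so nothing in the set fixes the size of the step. Compound 4 is expected to give a weaker result than compound 2, with a step of a 2.3-fold higher number from compound 2 to compound 4 (0.37 log units; beyond the scatter) beyond the scatter. The estimate for compound 4 is 40000 nM, spanning 15000 nM to 120000 nM.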

Compound 4, half-maximal inhibitory concentration: 21800 nM
Beside the measured number, compound 4's estimate is 1.8-fold (0.26 log units) above it; the range from low to high includes it.
By their numbers in this assay, from the lowest: compounds 3, 2 and 4 (each within the scatter of the next, the first and the last beyond it); then compound 1.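

In this assay, putting methyl in place of 4-methylphenyl on a carbonyl carbon gives a 1.3-fold higher number from compound 2 to compound 4 (0.11 log units; within the scatter) and so leaves the two compounds level. For this pair, the aromatic ring at this place is therefore not needed to keep the number where it stands. No measurement offered here explains this result.

The compounds shown leave open whether an amine, a carboxylic acid or a longer chain on this carbonyl carbon would keep the number level or shift it beyond the scatter.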